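The source may hold more compounds than are shown below. What is called first, only, known or untested is meant among the compounds shown, and "the series" means these compounds.

The measured compounds, one by one:

Among the measured compounds shown here, compound 1 `Cc1cc(C)nc(NS(=O)(=O)c2ccc(N3C(=O)/C(=C/c4coc5ccccc5c4=O)N=C3c3ccc(Cl)cc3)cc2)n1` is the only one with a number; in a functional assay on MCF7 cells (Homo sapiens) for cytotoxicity, read by sulforhodamine B assay, with a stated time of 72 h (a higher number here means a weaker inhibitor, a lower number a stronger inhibitor), compound 1 gives 93900 nM.

Compound 2 `Cc1cc(NS(=O)(=O)c2ccc(N3C(=O)/C(=C/c4coc5ccccc5c4=O)N=C3c3ccc(Cl)cc3)cc2)no1` reaches only a limit of this assay, which for compound 2 is > 100000 nM.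

Compound 3 `Cc1cc(C)nc(NS(=O)(=O)c2ccc(NC3=NC(=O)/C(=C\c4coc5ccccc5c4=O)S3)cc2)n1` likewise reaches only a limit, which for compound 3 is > 100000 nM.

The change from compound 1 to compound 2 is 5-methyl-1,2-oxazol-3-yl in place of 4,6-dimethylpyrimidin-2-yl on a sulfonamide nitrogen. It made a step of an at least 1.0-fold higher number from compound 1 to compound 2 (0.02 log units; that floor lies within the scatter), a step that rests on a limit rather than on two numbers, as the limit of > 100000 nM in this assay, at which 2 of the 3 values shown sit, shows.

Compound 3 carries a different core from compound 1; how the two cores differ is not broken down here. Compound 4 `Cc1cc(NS(=O)(=O)c2ccc(NC3=NC(=O)/C(=C\c4coc5ccccc5c4=O)S3)cc2)no1` is the not yet measured partner of compound 3, and the change from compound 3 to compound 4 is 5-methyl-1,2-oxazol-3-yl in place of 4,6-dimethylpyrimidin-2-yl on a sulfonamide nitrogen. The place of this change is the same as in the pair of compound 1 and compound 2, so it is the same change made on a second core; among the four compounds it occurs twice in all.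

Compound 3 already sits at the limit in this assay, so the expected step from compound 3 to compound 4 is a step that the limit leaves unreadable from compound 3 to compound 4, resting on the earlier step of an at least 1.0-fold higher number from compound 1 to compound 2 (0.02 log units; that floor lies within the scatter) and on the limit (the limit of > 100000 nM in this assay, at which 2 of the 3 values shown sit). For compound 4 the expected value in this assay is 150000 nM, estimated to lie between 50000 nM and 500000 nM, most likely reported only as a limit.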

Compound 4, half-maximal inhibitory concentration: > 100000 nM
Compound 4 was reported as a limit; the forecaster's own chance of this, stated with the estimate: 85%; the middle value lies beyond the limit too.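

Compound 3 and compound 4 both sit at a limit of this assay and neither has an exact number, so no step can be read between them: the limit of > 100000 nM in this assay, at which 3 of the 4 values shown sit.

The compounds shown leave open whether 5-methyl-1,2-oxazol-3-yl in place of 4,6-dimethylpyrimidin-2-yl on a sulfonamide nitrogen changes the read-out on either core, and how far past the limit compound 2, compound 3 and compound 4 lie.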